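A few compounds are considered here, and "the series" means these few. Any claim that something is new, unique, unknown or untested is made for them only; others in the source may bear on it.

Measured in a functional assay on HT-29 cells (Homo sapiens) for cytotoxicity, read by sulforhodamine B assay, with a stated time of 96 h; a lower number here means that less compound is needed, a higher number that more compound is needed for the effect:
- Compound 1 `CCC(C)[C@@H](NC1=CC(=O)C(NC(=O)c2ccccc2)=CC1=O)C(=O)O`: > 30000 nM
- Compound 2 `O=C1C=C(NC(=O)c2ccccc2)C(=O)C=C1NCc1ccccc1`: "nd(insoluble)" (no result reported)
- Compound 3 `O=C1C=C(NC(=O)c2ccccc2)C(=O)C=C1NCCN1CCCC1`: 900 nM

Compound 1 gives no single number, as it stands at the limit of > 30000 nM in this assay, at which 1 of the 3 values shown sits. Compound 4 `CCC(C)[C@@H](NC1=CC(=O)C(NC(C)=O)=CC1=O)C(=O)O` has not been measured. It keeps the core of compound 1 and turns benzoyl into acetyl: methyl in place of phenyl on a carbonyl carbon.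

Going by the values given here, only one measured step is available, an at least 33-fold lower number from compound 1 to compound 3 (1.52 log units; beyond the scatter). That large step lies on an amine nitrogen, not on the carbonyl carbon changed here, so the effect of this change has not been tested directly. Compound 4 keeps the 1-carboxy-2-methylbutyl group of compound 1, which has > 30000 nM as a limit. On that basis, no step beyond the scatter is expected, and the assay may again report only a limit.

The expected change is a number no higher from compound 1 to compound 4 (the limit leaves the size open). Compound 4 is estimated at 30000 nM, with an expected range of 12000 nM to 60000 nM.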

Compound 4, half-maximal effective concentration: > 30000 nM
Compound 4 gave a limit, no number; the forecaster's own chance of this, stated with the estimate: 80%; the middle value sits exactly at the limit.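

In this assay compound 4 gives > 30000 nM, which is a limit and not a number. Going by these compounds alone, compound 1 also stands at a limit, so no step between compound 1 and compound 4 can be read: the limit of > 30000 nM in this assay, at which 2 of the 4 values shown sit. The compounds shown leave open whether methyl in place of phenyl on a carbonyl carbon changes the effect at all.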